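Taking the fluoro off compound 2: an expectation

The source may hold more compounds than are shown below. What is called first, only, known or untested is meant among the compounds shown, and "the series" means these compounds.

Measured so far in an assay on CHO cells for positive allosteric modulation of metabotropic glutamate receptor 5 (Homo sapiens), read by FLIPR; on this read-out higher numbers stand for an effect only at larger amounts of compound and lower numbers for an effect already at smaller amounts:
compound 1, `O=C(Nc1cccc(F)c1CN1C(=O)c2ccccc2C1=O)c1ccccn1`, gives > 100000 nM (a limit of the assay, not a number)
compound 2, `O=C(Nc1ccc(F)cc1CN1C(=O)c2ccccc2C1=O)c1ccccn1`, gives 1500 nM

Within the data shown here, compound 2 thus stands as the only measured number in this assay. For compound 1 the result is the limit of > 100000 nM in this assay, at which 1 of the 2 values shown sits; this is a limit only, and no number. Among the measured compounds shown here, no two measured compounds differ in just one place, so no measured step guides the change to the new compound.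

Compound 3, `O=C(Nc1ccccc1CN1C(=O)c2ccccc2C1=O)c1ccccn1`, differs from compound 2 by hydrogen in place of fluoro on an aromatic carbon of a six-membered aromatic ring of carbon only. The expected step in this assay from compound 2 to compound 3 is a 1.7-fold higher number from compound 2 to compound 3 (0.22 log units; within the scatter), a slight weakening, barely beyond the scatter. Compound 3 is therefore estimated at 2500 nM, expected between 800 nM and 8000 nM.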

Compound 3, half-maximal effective concentration: 13900 nM
Estimate against measurement, compound 3: 5.6-fold (0.75 log units) below; the whole stated range lies below it.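

In this assay, the fluoro para to a ((pyridin-2-yl)carbonyl)amino group clearly counts: hydrogen in its place gives a 9.3-fold higher number from compound 2 to compound 3 (0.97 log units; beyond the scatter), so compound 2 shows its effect at smaller amounts than compound 3. The same swap made at the other fluoro place on this ring runs the opposite way, giving an at least 7.1-fold lower number from compound 1 to compound 3 (0.85 log units; beyond the scatter), so among these compounds the outcome of the change depends on where the fluoro sits. For compound 1 the result is a limit and not a number: the limit of > 100000 nM in this assay, at which 1 of the 3 values shown sits.

The compounds shown leave open whether another group at the place of the fluoro in compound 2, such as chloro, methoxy or an amine, would match or surpass fluoro. Why the two steps run in opposite directions also stays open.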